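Chlorobenzyl purines on CAKI-1 cells: one amino exchange

The source may hold more compounds than are shown below. What is called first, only, known or untested is meant among the compounds shown, and "the series" means these compounds.

Measured compounds:
compound 1, `Nc1nc(Cl)c2ncn(Cc3ccc(CCl)cc3)c2n1`, 34700 nM
compound 2, `ClCc1cccc(Cn2cnc3c(Cl)nc(Cl)nc32)c1`, 22900 nM
compound 3, `ClCc1ccc(Cn2cnc3c(Cl)nc(Cl)nc32)cc1`, 46800 nM

The three compounds were tested in a functional assay on CAKI-1 cells (Homo sapiens) for cytotoxicity, read by sulforhodamine B assay, with a stated time of 48 h; a lower number here means that less compound is tolerated, a higher number that more compound is tolerated. In this assay compound 3 gives 46800 nM, and compound 1 gives 34700 nM. The two share a core and differ in one place, (amino in place of chloro on an aromatic carbon), and the step of a 1.3-fold lower number from compound 3 to compound 1 (0.13 log units; within the scatter) is small. Compound 2 gives 22900 nM; its core and the core of compound 3 contain the same atoms joined differently, and the difference between the two cores is not broken down here. The values of compound 2 and compound 1 lie close together, while the value of compound 3 stands further from that of compound 2.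

Compound 4, `Nc1nc(Cl)c2ncn(Cc3cccc(CCl)c3)c2n1`, has not yet been measured. It is related to compound 2 by amino in place of chloro on an aromatic carbon, the same change, at the same place, that leads from compound 3 to compound 1. Compound 4 is expected to give about 18000 nM in this assay, a step of a 1.3-fold lower number from compound 2 to compound 4 (0.10 log units; within the scatter), because the same change gave a 1.3-fold lower number from compound 3 to compound 1 (0.13 log units; within the scatter). Among the measured compounds shown here, a reasonable range for compound 4 is estimated from 8000 nM to 40000 nM, since the one earlier step was within the scatter and a single example gives no firm direction.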

Compound 4, concentration lethal to 50% of the cells: 15900 nM
Estimate against measurement, compound 4: 1.1-fold (0.05 log units) above; low and high end bracket the measured number.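

In this assay, putting amino in place of chloro on an aromatic carbon, between two ring nitrogen atoms, gives a 1.4-fold lower number from compound 2 to compound 4 (0.16 log units; within the scatter). Set beside the earlier case, the exchange reads alike on the two cores, so in this small set the step carries over from one core to the other: the same change on two cores in this assay, a 1.3-fold lower number (0.13 log units; within the scatter) from compound 3 to compound 1 and a 1.4-fold lower number (0.16 log units; within the scatter) from compound 2 to compound 4, 1.1-fold (0.03 log units) apart, within the scatter of two such steps

What this agreement shows is limited, since both steps lie within the scatter: on these two cores the exchange leaves the number within the scatter, but the pair establishes no real direction for the change, and two cores in one cell assay give no rule for other cores in the series or for other read-outs.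

The compounds shown hold only chloro or amino at this place, which leaves open how a methoxy group, a thiol or a longer amine such as dimethylamino would read there. From the compounds shown here alone, all four compounds also keep a chloro group or an amino group within the same pairing of cores, and it remains open whether the step would look the same on a core carrying a carboxylic acid or a longer chain in place of the chloro group meta to this place.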